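Hydroxy for methyl in a flat aryl series

A few compounds are considered here, and "the series" means these few. Any claim that something is new, unique, unknown or untested is made for them only; others in the source may bear on it.

In a functional assay (a higher number here means a weaker inhibitor, a lower number a stronger inhibitor), compound 1 `CC(C)=CCOc1ccc2c(c1)OC(c1ccc(Cl)cc1Cl)CC2=O` reads 5260 nM and compound 2 `CC(C)=CCOc1ccc2c(c1)OC(c1ccccc1Br)CC2=O` reads 3180 nM while compound 3 `CC(C)=CCOc1ccc2c(c1)OC(c1ccc(C)cc1)CC2=O` reads 4440 nM on the same core. Compound 3 lies within the scatter of both others, with a 1.2-fold lower number from compound 1 to compound 3 (0.07 log units; within the scatter) and a 1.4-fold higher number from compound 2 to compound 3 (0.14 log units; within the scatter) as its measured steps. Compound 4 `CC(C)=CCOc1ccc2c(c1)OC(c1ccc(O)cc1)CC2=O` replaces 4-methylphenyl with 4-hydroxyphenyl, hydroxy in place of methyl on an aromatic carbon as the counted change. Going by the values given here, the third aryl swap, a 1.7-fold lower number from compound 1 to compound 2 (0.22 log units; within the scatter) as well, stays within the scatter, but no measured step involves a hydroxy group. In this assay an estimated 1.3-fold lower number from compound 3 to compound 4 (0.10 log units; within the scatter) is expected, no step beyond the scatter, with direction open. Compound 4 is estimated at 3500 nM with an expected range of 1300 nM to 9000 nM for now.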

Compound 4, half-maximal inhibitory concentration: 6670 nM
The estimate for compound 4 lay 1.9-fold (0.28 log units) below the measured number; the range from low to high includes it.
By their numbers in this assay, from the lowest: compounds 2, 3, 1 and 4 (each within the scatter of the next, the first and the last beyond it).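

In this assay, hydroxy in place of methyl on this aromatic carbon gives a 1.5-fold higher number from compound 3 to compound 4 (0.18 log units; within the scatter), so this position takes a hydroxy group without a step beyond the scatter. The change from the 2,4-dichlorophenyl compound also stays within the scatter, at a 1.3-fold higher number from compound 1 to compound 4 (0.10 log units; within the scatter), and only the change from the 2-bromophenyl compound passes it, modestly, at a 2.1-fold higher number from compound 2 to compound 4 (0.32 log units; beyond the scatter). No supporting data bear on the reason for these numbers. From the compounds shown here alone, whether an amine or a carboxylic acid at this position would give a step beyond the scatter from compound 3 remains open. Also open, going by these compounds, is whether hydroxy for methyl gives a similar step with a longer chain on the shared core.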